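Working notes on amide variation in the shared core

The source may report more compounds than this note shows. Statements on the series, on what has been measured and on what is new or still open speak of the compounds shown alone.

In an ADME assay on Raji cells (Homo sapiens) for inhibition, with a stated time of 72 h (a lower number here means that less compound is needed, a higher number that more compound is needed for the effect), compound 1 `C/C=C/C(=O)Nc1cccc(-c2nc3ccccc3s2)c1` gives only a limit, > 25000 nM. Compound 2 `CC(C)(CCl)C(=O)Nc1cccc(-c2nc3ccccc3s2)c1` likewise returns a limit in this assay, > 25000 nM. The step that the two limits leave unreadable from compound 1 to compound 2 is therefore not readable in size, as both values sit at the limit of > 25000 nM in this assay, at which 2 of the 2 values shown sit. Compound 3 `O=C(Nc1cccc(-c2nc3ccccc3s2)c1)c1cnccc1Cl` brings (4-chloropyridin-3-yl in place of 1-(chloromethyl)-1-methylethyl on a carbonyl carbon). Among the compounds with values here, no measured step in this assay gives a readable size to carry over, so compound 3 is expected to remain near the limit. The estimate for compound 3 in this assay is 30000 nM, with a range of 8000 nM to 100000 nM. This estimate means an expected step that the limit leaves unreadable from compound 2 to compound 3.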

Compound 3, half-maximal effective concentration: 12000 nM
The estimate for compound 3 lay 2.5-fold (0.40 log units) above the measured number; the range from low to high includes it.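

In this assay, within the data shown here, the place on the carbonyl carbon now gives a readable response: 4-chloropyridin-3-yl, the only group of the three with a ring, gives an at least 2.0-fold lower number from compound 2 to compound 3 (0.31 log units; beyond the scatter) and also an at least 2.0-fold lower number from compound 1 to compound 3 (0.31 log units; beyond the scatter) in the comparison with prop-1-en-1-yl. Both steps remain lower bounds, because the two earlier compounds give only a limit: the limit of > 25000 nM in this assay, at which 2 of the 3 values shown sit.

From the compounds shown here alone, whether the step follows the ring, its nitrogen or its chlorine remains open. A plain phenyl or an unsubstituted pyridin-3-yl on the same carbonyl carbon would separate these.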